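The source may report more compounds than this note shows. Statements on the series, on what has been measured and on what is new or still open speak of the compounds shown alone.

Measured so far in a functional assay on PC-3 cells (Homo sapiens) for cytotoxicity, read by MTT assay, with a stated time of 72 h; on this read-out higher numbers stand for weaker inhibition and lower numbers for stronger inhibition:
compound 1 `O=C(Nc1ccc(Oc2ccnc3[nH]ccc23)cc1)c1nn(-c2ccc(Br)cc2F)ccc1=O` gives 12800 nM
compound 2 `Cn1ccc2c(Oc3ccc(NC(=O)c4nn(-c5ccc(Br)cc5F)ccc4=O)cc3)ccnc21` gives 20500 nM
compound 3 `Cc1cc(=O)n(-c2ccccc2OC(F)(F)F)nc1C(=O)Nc1ccc(Oc2ncnc3[nH]ccc23)cc1` gives 22500 nM

All three numbers lie close together. Compound 1 and compound 2 share one core and differ at a single point: methyl in place of hydrogen on an aromatic nitrogen. That change made a 1.6-fold higher number from compound 1 to compound 2 (0.20 log units; within the scatter). Compound 3 carries a different core; how its core differs from the core of compound 1 is not broken down here. Set against compound 2, compound 3 gives a number within the scatter of it, and the same holds against compound 1, so no order among the three can be read from this assay.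

Compound 4 `Cc1cc(=O)n(-c2ccccc2OC(F)(F)F)nc1C(=O)Nc1ccc(Oc2ncnc3c2ccn3C)cc1` is not yet measured. It arises from compound 3 by methyl in place of hydrogen on an aromatic nitrogen, the same change, at the same kind of place, that leads from compound 1 to compound 2. Since that earlier step was a 1.6-fold higher number from compound 1 to compound 2 (0.20 log units; within the scatter), a step of similar size, within the scatter, is expected from compound 3 to compound 4 in this assay, namely a 1.3-fold higher number from compound 3 to compound 4 (0.12 log units; within the scatter). The number for compound 4 is estimated at 30000 nM. The range expected for compound 4 runs from 15000 nM to 60000 nM.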

Compound 4, half-maximal inhibitory concentration: 5160 nM
Estimate against measurement, compound 4: 5.8-fold (0.76 log units) above; measured number outside the range, below it.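

In this assay, methyl in place of hydrogen on an aromatic nitrogen gives a 4.4-fold lower number from compound 3 to compound 4 (0.64 log units; beyond the scatter), so on this core the change goes with stronger inhibition. The effect of this change does not carry over as a fixed step between the two cores: the same change on two cores in this assay, a 1.6-fold higher number (0.20 log units; within the scatter) from compound 1 to compound 2 and a 4.4-fold lower number (0.64 log units; beyond the scatter) from compound 3 to compound 4, 7.0-fold (0.84 log units) apart, beyond the scatter of two such steps. This shows that the step on the core of compound 1 does not predict the step on the core of compound 3, but two pairs do not show which difference between the cores goes with the gap, nor how the change would behave on a third core.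

The compounds shown leave open whether an ethyl group, a longer chain or a chain ending in an amine on the same aromatic nitrogen would extend the step seen on the core of compound 3. They also leave open whether any such group would give a step beyond the scatter on the core of compound 1.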